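Swapping the Ester Terminus for Trifluoromethyl on Compound 3

A few compounds are considered here, and "the series" means these few. Any claim that something is new, unique, unknown or untested is made for them only; others in the source may bear on it.

Of the compounds shown here, three of a shared core have been measured in a functional assay on MCF7 cells (Homo sapiens) for antiproliferative activity, tested at 1 uM; a higher number here means more inhibition at the concentration tested (going by the name of the read-out), a lower number less inhibition. Compound 1 `Cc1c(CO/N=C/c2c(-c3ccccc3)nn(-c3ccccc3)c2Oc2ccc(Cl)cc2)cccc1-c1ccccc1` gives -17.5%. Compound 2 `Cc1nn(-c2ccccc2)c(Oc2ccc(Cl)cc2)c1/C=N/OCc1ccc(C(=O)OC(C)(C)C)cc1` gives -8.4%, and compound 3 `CC(C)c1nn(-c2ccccc2)c(Oc2ccc(Cl)cc2)c1/C=N/OCc1ccc(C(=O)OC(C)(C)C)cc1` gives -4.9%. Among the measured compounds shown here, compound 3 thus lies within the scatter of compound 2 and beyond the scatter of compound 1; the only single-place step between measured compounds, a number 3.5 percentage points higher from compound 2 to compound 3 (within the scatter), concerns the group on an aromatic carbon of the core and changes nothing outside the scatter.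

Compound 4 `CC(C)c1nn(-c2ccccc2)c(Oc2ccc(Cl)cc2)c1/C=N/OCc1ccc(C(F)(F)F)cc1` is the next compound and differs from compound 3 in one place: trifluoromethyl in place of tert-butoxycarbonyl on an aromatic carbon. For the measured compounds named here, no measured step touches this position, so nothing in the numbers points to a change in either direction. Compound 4 is therefore expected to land near compound 3, with a number 0.1 percentage points lower from compound 3 to compound 4 (within the scatter) not beyond the scatter. The estimate for compound 4 in this assay is -5%, within a range from -20% to 10%.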

Compound 4, a percentage reported as inhibition, at one concentration (the size of the read-out at that concentration, not a potency): -1.9%
The estimate for compound 4 lay 3.1 percentage points below the measured number, and the stated range covers the measured number.
By their numbers in this assay, from the lowest: compounds 1, 2, 3 and 4 (each within the scatter of the next, the first and the last beyond it).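

Trifluoromethyl in place of tert-butoxycarbonyl, on the aromatic carbon para to a large group, gives in this assay a number 3 percentage points higher from compound 3 to compound 4 (within the scatter) and is the only step shown at this position. The change from 7 heavy atoms and 2 hydrogen-bond acceptors to 4 heavy atoms and no hydrogen-bond acceptors therefore leaves the two compounds within the scatter of each other, and both numbers stay negative, as compound 3 gives -4.9% and compound 4 gives -1.9% in this read-out. No other measurement is available to bear on this result.

Going by these compounds, whether a carboxylic acid, an amine or a nitrile on that aromatic carbon would move the number beyond the scatter remains open. Also open, on these data alone, is whether trifluoromethyl would read the same with methyl in place of isopropyl on the shared core.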